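Swapping a meta-fluoro for a para-chloro on the pendant phenyl

The source may report more compounds than this note shows. Statements on the series, on what has been measured and on what is new or still open speak of the compounds shown alone.

Compound 1 `COc1cc(-n2cnc3ccc(-c4cccc(N)c4)cc32)cc(OC)c1OC`: 180 nM
Compound 2 `COc1cc(-n2cnc3ccc(-c4cccc(F)c4)cc32)cc(OC)c1OC`: 2350 nM
Compound 3 `COc1cc(-c2ccc3ncn(-c4cc(OC)c(OC)c(OC)c4)c3c2)cc(OC)c1OC`: > 10000 nM (a limit, not a number)

Of the compounds shown here, three sharing one core have been measured in a functional assay on MCF7 cells (Homo sapiens) for antiproliferative activity, read by MTT assay, with a stated time of 72 h; on this read-out higher numbers stand for weaker inhibition and lower numbers for stronger inhibition. Compound 1 gives 180 nM. Among the compounds with values here, compound 2 gives 2350 nM, the highest of the two numbers reported; its only neighbour is compound 1, and the step of a 13-fold higher number from compound 1 to compound 2 (1.12 log units; beyond the scatter) is large. For compound 3 the assay reports only a limit, > 10000 nM, and the limit of > 10000 nM in this assay, at which 1 of the 3 values shown sits, is where that limit sits.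

The next compound, compound 4 `COc1cc(-n2cnc3ccc(-c4ccc(Cl)cc4)cc32)cc(OC)c1OC`, differs from compound 2 by 4-chlorophenyl in place of 3-fluorophenyl on an aromatic carbon. Within the data shown here, no measured step touches this kind of change: the one step known, from compound 1 to compound 2, swaps an amino for a fluoro, and nothing recorded compares one halogen with another or a change of position on that ring. Among the measured compounds shown here, the sole guide is that compound 2 itself sits well away from the stronger compound 1, so a halogen at this position has so far given a weak number. Compound 4 is therefore expected to stay near compound 2, with the step of a 1.1-fold higher number from compound 2 to compound 4 (0.03 log units; within the scatter) estimated to be within or only just beyond the scatter. The estimate for compound 4 in this assay is 2500 nM, between 800 nM and 8000 nM.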

Compound 4, half-maximal inhibitory concentration: 1320 nM
The estimate for compound 4 lay 1.9-fold (0.28 log units) above the measured number, within the range that was stated.
By their numbers in this assay, from the lowest: compound 1; then compounds 4 and 2 (each within the scatter of the next). At a limit, above all of these: compound 3.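

Exchanging 3-fluorophenyl for 4-chlorophenyl on the shared core alters both the halogen and its place on the ring. Even so, this assay shows a 1.8-fold lower number from compound 2 to compound 4 (0.25 log units; within the scatter) and so does not separate these two halogen-bearing compounds, which means this double change has no clear effect on the number here. The comparison with the amino-bearing compound adds a second finding, a 7.3-fold higher number from compound 1 to compound 4 (0.87 log units; beyond the scatter), so a different halogen in a different place also leaves the number well short of the one given by 3-aminophenyl, and nothing measured here bears on why this swap matters so little.

Because the halogen and its place change together, the compounds shown leave open whether either one matters alone, and whether the amino group would keep its advantage if it sat where the chloro group of compound 4 sits. Fluoro and chloro groups exchanged between those two places would separate these questions, while a hydroxyl group or a carboxylic acid on the same ring would test whether the advantage extends beyond the amino group.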